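This account rests on a few compounds, and the source may have more. Where it says the series, first, only, none or still open, it means among the compounds named here.

All three measured compounds were tested in an assay on isolated protein for inhibition of phosphatidylinositol 4,5-bisphosphate 3-kinase catalytic subunit beta isoform (Homo sapiens), read by 33P incorporation, with a stated time of 60 min; on this read-out lower numbers stand for stronger inhibition and higher numbers for weaker inhibition:

compound 1, `Cc1ccc(Br)cc1S(=O)(=O)N(C)/N=C/c1cnn2ccc(C#N)cc12`: 620 nM
compound 2, `Cc1ccc([N+](=O)[O-])cc1C(=O)N(C)/N=C/c1cnn2ccc(C#N)cc12`: 68 nM
compound 3, `COc1ccc([N+](=O)[O-])cc1S(=O)(=O)N(C)/N=C/c1cnn2ccc(C#N)cc12`: 63 nM

Compound 1 has the highest of these three numbers, with compound 2 and compound 3 both coming out clearly lower, beyond the scatter. Within the data shown here, no single traced step links these pairs, so only the values themselves can be read. The compound not yet measured is compound 4, `CC(=O)Nc1ccc(C)c(S(=O)(=O)N(C)/N=C/c2cnn3ccc(C#N)cc23)c1`. It differs from compound 1 by acetamido in place of bromo on an aromatic carbon. Among the measured compounds shown here, with no matching step among the measured compounds, the size of this change can only be estimated. A moderate decrease in number is expected, the step of a 3.1-fold lower number from compound 1 to compound 4 (0.49 log units; beyond the scatter) being the estimate. For compound 4 the expected value is 200 nM, with a range from 60 nM to 650 nM.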

Compound 4, half-maximal inhibitory concentration: > 1000 nM
Compound 4 gave a limit, no number; the forecaster's own chance of this, stated with the estimate: 0%; at least 5.0-fold (0.69 log units) between middle value and limit.
By their numbers in this assay, from the lowest: compounds 3 and 2 (each within the scatter of the next); then compound 1. At a limit, above all of these: compound 4.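

At this place on the ring, meta to a large group and para to a methyl group, compound 4 gives a limit of the assay rather than a number: the limit of > 1000 nM in this assay, at which 1 of the 4 values shown sits. Acetamido in place of bromo therefore shows no gain, and the change can be read only as an at least 1.6-fold higher number from compound 1 to compound 4 (0.20 log units; that floor lies within the scatter). On these data alone, its true size remains unknown, and with that floor inside the scatter, even a real loss is not established.

As far as these compounds go, whether an amine or a carboxylic acid at this place would give a lower number than bromo remains open.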